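Oxolan-3-yl for Trifluoroethyl at the Aromatic Nitrogen

The source may report more compounds than this note shows. Statements on the series, on what has been measured and on what is new or still open speak of the compounds shown alone.

Three compounds built on one shared core were tested in a toxicity assay on HT-29 cells (Homo sapiens) for cytotoxicity; on this read-out lower numbers stand for higher toxicity in this test and higher numbers for lower toxicity in this test. Compound 1 `CC(C)Cn1nc(C(=O)N[C@H]2COc3ccccc3N(C)C2=S)nc1Cc1ccccc1` carries an isobutyl group on an aromatic nitrogen; in this assay compound 1 reaches only the limit > 100000 nM, not a number. Compound 2 `CN1C(=S)[C@@H](NC(=O)c2nc(Cc3ccccc3)n(CCC(F)(F)F)n2)COc2ccccc21` bears a 3,3,3-trifluoropropyl group on that nitrogen, and in this assay compound 2 again returns only the limit > 100000 nM. Compound 3 `CN1C(=S)[C@@H](NC(=O)c2nc(Cc3ccccc3)n(C3CCCCC3)n2)COc2ccccc21`, with cyclohexyl on the aromatic nitrogen, likewise stops in this assay at the limit > 100000 nM. The steps a step that the two limits leave unreadable from compound 1 to compound 2, a step that the two limits leave unreadable from compound 1 to compound 3 and a step that the two limits leave unreadable from compound 2 to compound 3 therefore cannot be sized; what the three measurements share is the limit of > 100000 nM in this assay, at which 3 of the 3 values shown sit. Compound 2 thus stands where both companions stand, at a limit rather than a number.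

Compound 4 `CN1C(=S)[C@@H](NC(=O)c2nc(Cc3ccccc3)n(CC3CCOC3)n2)COc2ccccc21` differs from compound 2 by oxolan-3-yl in place of 2,2,2-trifluoroethyl on a saturated chain carbon bound to an aromatic nitrogen. The measured changes at this position, a step that the two limits leave unreadable from compound 1 to compound 2, a step that the two limits leave unreadable from compound 1 to compound 3 and a step that the two limits leave unreadable from compound 2 to compound 3, are all unreadable and bear on the new change only by leaving every value at the limit. No step beyond the scatter is expected, and the estimated step is a step that the limit leaves unreadable from compound 2 to compound 4. Compound 4 is expected to give about 150000 nM in this assay, within 50000 nM to 500000 nM, most probably again as a limit.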

Compound 4, half-maximal cytotoxic concentration: > 100000 nM
Compound 4: only a limit was reported; the forecaster's own chance of this, stated with the estimate: 80%; the middle value lies beyond the limit too.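

In this assay compound 4 ends at a limit, as do compound 1, compound 2 and compound 3, so no new step can be read: the limit of > 100000 nM in this assay, at which 4 of the 4 values shown sit.

Still open, going by these compounds, is whether any group on this aromatic nitrogen gives a readable number in this assay at all, and so how large these steps are.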